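A few compounds are considered here, and "the series" means these few. Any claim that something is new, unique, unknown or untested is made for them only; others in the source may bear on it.

Compound 1 `O=C(Nc1cccc(C(F)(F)F)c1)N[C@H]1CC[C@H](Oc2cccc(C(F)(F)F)c2)CC1`: 1300 nM
Compound 2 `CSc1ccc(NC(=O)N[C@H]2CC[C@H](Oc3ccc(F)cc3)CC2)cc1`: > 20000 nM

Both compounds were tested in a functional assay on CRL2813 cells (Homo sapiens) for cytotoxicity, read by sulforhodamine B assay, with a stated time of 5 days; on this read-out lower numbers stand for stronger inhibition and higher numbers for weaker inhibition. Compound 1 gives a definite number in this assay. For compound 2 the result is a limit rather than a number, (the limit of > 20000 nM in this assay, at which 1 of the 2 values shown sits). Compound 3 `COc1ccc(NC(=O)N[C@H]2CC[C@H](Oc3ccc(F)cc3)CC2)cc1` has not yet been measured; it differs from compound 2 by methoxy in place of methylsulfanyl on an aromatic carbon. Going by the values given here, no step between two measured compounds is available to guide this change, and compound 2 itself offers only a limit, so there is little to build on. The change is expected to give a step that the limit leaves unreadable from compound 2 to compound 3, a shift no larger than the usual scatter and with no clear direction. Compound 3 is therefore estimated at 25000 nM, in a range from 8000 nM to 60000 nM, and it is most likely to be reported again only as a limit in this assay.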

Compound 3, half-maximal inhibitory concentration: > 20000 nM
Compound 3: a limit, no number; the forecaster's own chance of this, stated with the estimate: 70%; the middle value lies beyond the limit too.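

In this assay, going by these compounds alone, compound 2 and compound 3 both give a limit rather than a number, so no step between them can be read: the limit of > 20000 nM in this assay, at which 2 of the 3 values shown sit. The compounds shown leave open whether methoxy in place of methylsulfanyl changes cytotoxicity at all, in either direction.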